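Dropping the carbonyl from compound 3

The source may report more compounds than this note shows. Statements on the series, on what has been measured and on what is new or still open speak of the compounds shown alone.

Values in a functional assay on HL-60 cells (Homo sapiens) for activation; on this read-out lower numbers stand for an effect already at smaller amounts and higher numbers for an effect only at larger amounts of compound:
- compound 1 `CCCCCCCCCCCCNCC(N)CCN`: 631 nM
- compound 2 `CCCCCCCCCCCCNCCN`: 1000 nM
- compound 3 `CCCCCCCCCCCCNC(=O)C(N)CN`: 2510 nM

Compound 3 has the highest number of the three, so it needs the largest amount to act. Compound 4 `CCCCCCCCCCCCNCCN=C(N)N` is unmeasured. It differs from compound 3 by a group of 6 heavy atoms (3 carbon, 3 nitrogen; no ring) in place of a group of 6 heavy atoms (3 carbon, 2 nitrogen, 1 oxygen; no ring), on an amine nitrogen, and this removes the carbonyl. Neither compound 1 nor compound 2 has that carbonyl, and the measured steps to compound 3 are both modest: a 2.5-fold higher number from compound 2 to compound 3 (0.40 log units; beyond the scatter) and a 4.0-fold higher number from compound 1 to compound 3 (0.60 log units; beyond the scatter). The step of a 1.6-fold higher number from compound 1 to compound 2 (0.20 log units; within the scatter) shows that the amine side chain can change with little effect. Among the compounds with values here, no measured compound carries the entering group, which leaves the outcome uncertain. In this assay, a modest fall is expected, estimated as a 2.5-fold lower number from compound 3 to compound 4 (0.40 log units; beyond the scatter). For compound 4 the estimate is 1000 nM, with an expected range of 320 nM to 3200 nM.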

Compound 4, half-maximal effective concentration: 1000 nM
Estimate against measurement, compound 4: no gap at the digits printed; the range from low to high includes it.
By their numbers in this assay, from the lowest: compounds 1, 2 and 4 (each within the scatter of the next); then compound 3.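

In this assay, the group entering on the amine nitrogen removes the carbonyl and gives a 2.5-fold lower number from compound 3 to compound 4 (0.40 log units; beyond the scatter). The other two steps, no change at the digits printed from compound 2 to compound 4 (within the scatter) and a 1.6-fold higher number from compound 1 to compound 4 (0.20 log units; within the scatter), lie within the scatter, so among these four compounds only compound 3, the one with the carbonyl, stands apart, and three different carbonyl-free side chains cannot be told apart. Nothing available explains this difference. A carboxylic acid at the end of this side chain remains untested among the compounds shown. So does a shorter carbon chain on the other side of the amine nitrogen.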